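The source may report more compounds than this note shows. Statements on the series, on what has been measured and on what is new or still open speak of the compounds shown alone.

The measured compounds:

Compound 1, `CC(C)(C)CC[C@H](c1ccc(C(=O)NCc2nn[nH]n2)cc1)N1C(=O)C(c2cncc(Cl)c2)=N[C@]12CC[C@@H](C(C)(C)C)CC2`, in an assay on CHO cells for displacement of a labelled ligand from Glucagon receptor (Homo sapiens), read by scintillation counting, with a stated time of 60 min (on this read-out higher numbers stand for weaker inhibition and lower numbers for stronger inhibition), gives 38 nM.
Compound 2, `CC(C)(C)CC[C@H](c1ccc(C(=O)NCc2nn[nH]n2)cc1)N1C(=O)C(c2ccc(C(F)(F)F)cc2)=N[C@]12CC[C@@H](C(C)(C)C)CC2`, gives 7 nM.
Compound 3, `CC(C)(C)[C@H]1CC[C@]2(CC1)N=C(c1cccc(Cl)c1)C(=O)N2Cc1ccc(C(=O)NCCC(=O)O)cc1`, gives 770 nM.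

Compound 2 has the lowest number of the three, so on this read-out it is the strongest inhibitor shown. Within the data shown here, the only change from compound 1 to compound 2 is the aromatic group on the carbon with a double bond to nitrogen, and that change gave a 5.4-fold lower number from compound 1 to compound 2 (0.73 log units; beyond the scatter). Compound 3 shares the core but differs in several places at once, so its value can only be set side by side with the others and not read as a single step.

Compound 4, `CC(C)(C)CC[C@H](c1ccc(C(=O)NCc2nn[nH]n2)cc1)N1C(=O)C(c2ccc(F)cc2)=N[C@]12CC[C@@H](C(C)(C)C)CC2`, differs from compound 2 in one place: fluoro in place of trifluoromethyl on an aromatic carbon. Among the measured compounds shown here, no measured pair changes the group at this position, so the step from compound 1 to compound 2 is the only evidence that this part of the molecule matters, and it does not show which way a smaller group would move the number. A modest rise in the number, or none beyond the scatter, is therefore expected; the expected step is a 2.9-fold higher number from compound 2 to compound 4 (0.46 log units; beyond the scatter). Compound 4 is estimated at 20 nM, within 7 nM to 60 nM.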

Compound 4, half-maximal inhibitory concentration: 13 nM
Beside the measured number, compound 4's estimate is 1.5-fold (0.19 log units) above it; the range from low to high includes it.
By their numbers in this assay, from the lowest: compounds 2 and 4 (each within the scatter of the next); then compound 1; then compound 3.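

In this assay the change from trifluoromethyl to fluoro gives a 1.9-fold higher number from compound 2 to compound 4 (0.27 log units; within the scatter) and so separates neither group from the other: this position tolerates the loss of most of the group's heavy atoms, at least in this pair. The step of a 2.9-fold lower number from compound 1 to compound 4 (0.47 log units; beyond the scatter) shows that the gain over 5-chloropyridin-3-yl is not unique to 4-(trifluoromethyl)phenyl, since 4-fluorophenyl also gives a lower number than that ring. Nothing available here accounts for these results.

From the compounds shown here alone, what a bare hydrogen, a methoxy group or an amine would do at this position remains open. Also open, going by these compounds, is whether fluoro and trifluoromethyl would stay this close with the carboxylic acid side chain of compound 3 in place of the tetrazole-bearing amide.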